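Changing the sulfonyl aryl of a sulfonamide orexin antagonist

The source may report more compounds than this note shows. Statements on the series, on what has been measured and on what is new or still open speak of the compounds shown alone.

Compound 1 `CCN(CC)C(=O)CN(c1ccc(C)cc1)S(=O)(=O)c1cccc(Cl)c1` is the weakest of the three measured compounds: in a functional assay on CHO cells for inhibition of Orexin receptor type 2 (Homo sapiens), read by FLIPR and calcium flux (a lower number here means a stronger inhibitor, a higher number a weaker inhibitor), compound 1 gives 139 nM. Compound 2 `CCN(C(=O)CN(c1cc(N(C)C)ccc1Cl)S(=O)(=O)c1ccc(OC)c(OC)c1)c1cccc(C)n1` gives 5 nM, and compound 3 `CCN(C(=O)CN(c1cc(N(C)C)ccc1Cl)S(=O)(=O)c1ccc(OC)c(OC)c1)c1ccn(C)n1` gives 7 nM, both far stronger than compound 1. Within the data shown here, the only measured single change, a 1.4-fold higher number from compound 2 to compound 3 (0.15 log units; within the scatter), concerns the amide-type nitrogen and leaves the sulfonyl aryl untouched. Compound 4 `CCN(CC)C(=O)CN(c1ccc(C)cc1)S(=O)(=O)c1ccc(C#N)cc1` differs from compound 1 by 4-cyanophenyl in place of 3-chlorophenyl on a sulfonyl sulfur. Among the measured compounds shown here, no measured step bears on this change, and compounds 2 and 3 share one sulfonyl aryl between them, so the expected step is small and of no firm direction. The step of a 1.3-fold higher number from compound 1 to compound 4 (0.11 log units; within the scatter) is therefore estimated as close to none beyond the scatter. In this assay compound 4 is expected to give 180 nM, with a range from 45 nM to 700 nM.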

Compound 4, half-maximal inhibitory concentration: 1190 nM
Estimate against measurement, compound 4: 6.6-fold (0.82 log units) below; the whole stated range lies below it.
By their numbers in this assay, from the lowest: compounds 2 and 3 (each within the scatter of the next); then compound 1; then compound 4.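

Compound 1's sulfonyl aryl proves not to be indifferent: 4-cyanophenyl in place of 3-chlorophenyl on a sulfonyl sulfur gives an 8.6-fold higher number from compound 1 to compound 4 (0.93 log units; beyond the scatter) in this assay. Among these compounds, this is the only measured step at this position, and it runs towards a weaker inhibitor. No measured evidence here accounts for the loss.

The change swaps both the group and its printed ring position, so 3-cyanophenyl or 4-chlorophenyl would be needed to separate the two. Going by these compounds, whether the same swap would act alike on the core of compound 2 also stays open.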